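Amide variation on the shared core of compound 1

The compounds below may be only part of what the source reports. "The series", "measured", "known", "first", "only" and "open" are said of these compounds alone.

Measured compounds:
- compound 1, `CCC(=O)Nc1c(C(O)(C(F)(F)F)C(F)(F)F)ccc2ccccc12`: 8.91 nM
- compound 2, `C/C=C/C(=O)Nc1c(C(O)(C(F)(F)F)C(F)(F)F)ccc2ccccc12`: 49 nM
- compound 3, `O=C(Nc1c(C(O)(C(F)(F)F)C(F)(F)F)ccc2ccccc12)C1CC1`: 126 nM

The three compounds share one core and differ only in the group on the carbonyl carbon of the amide. In a functional assay (Sus scrofa) with sulfonylurea receptors; K-ATP channels (Homo sapiens) as the target (on this read-out lower numbers stand for an effect already at smaller amounts and higher numbers for an effect only at larger amounts of compound), compound 1 gives 8.91 nM and stands lowest. Compound 3 gives 126 nM, the highest of the three numbers; its nearest neighbour is compound 2 with 49 nM.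

The unmeasured compound 4, `O=C(Nc1c(C(O)(C(F)(F)F)C(F)(F)F)ccc2ccccc12)c1cccc([N+](=O)[O-])c1`, follows from compound 3 by 3-nitrophenyl in place of cyclopropyl on a carbonyl carbon. Among the measured compounds shown here, no measured step puts an aromatic group on that carbonyl carbon, so the expectation rests on the general drift of the series: a 5.5-fold higher number from compound 1 to compound 2 (0.74 log units; beyond the scatter), a 14-fold higher number from compound 1 to compound 3 (1.15 log units; beyond the scatter) and a 2.6-fold higher number from compound 2 to compound 3 (0.41 log units; beyond the scatter). Every change away from ethyl so far raised the number, and the larger group in compound 4 is taken to continue that direction, though the size is uncertain and could fall within the scatter.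

For compound 4 a number of 250 nM is estimated, with a range from 60 nM to 1500 nM. This estimate corresponds to a 2.0-fold higher number from compound 3 to compound 4 (0.30 log units; within the scatter).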

Compound 4, half-maximal effective concentration: 427 nM
Compound 4: middle estimate off by 1.7-fold (0.23 log units), on the low side; low and high end bracket the measured number.
By their numbers in this assay, from the lowest: compound 1; then compound 2; then compound 3; then compound 4.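

In this assay, replacing cyclopropyl with 3-nitrophenyl on the carbonyl carbon gives a 3.4-fold higher number from compound 3 to compound 4 (0.53 log units; beyond the scatter), so an aromatic ring at this position continues the upward run of numbers rather than reversing it. Measured against the two other acyl groups, the same position gives an 8.7-fold higher number from compound 2 to compound 4 (0.94 log units; beyond the scatter) and a 48-fold higher number from compound 1 to compound 4 (1.68 log units; beyond the scatter), the second being the widest gap in the series, and ethyl remains the group with the lowest number of the four. Nothing available bears on why the number rises with these changes.

From the compounds shown here alone, it remains open whether the ring itself or its nitro group accounts for the step from cyclopropyl, a question that a plain phenyl group on the carbonyl carbon would address. Also open, going by these compounds, is whether methyl or a longer chain such as butyl would give a number below that of ethyl.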